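Swapping the para group on a pyrazoline cytotoxicity series

The source may hold more compounds than are shown below. What is called first, only, known or untested is meant among the compounds shown, and "the series" means these compounds.

Three compounds have numbers in a functional assay on PC-3 cells (Homo sapiens) for cytotoxicity, read by sulforhodamine B assay, with a stated time of 48 h; on this read-out lower numbers stand for stronger inhibition and higher numbers for weaker inhibition:

Compound 1 `CC(=O)N1N=C(c2ccccc2)CC1c1ccc(N(C)C)cc1` gives 7880 nM.
Compound 2 `CC(=O)N1N=C(c2ccco2)CC1c1ccc(Cl)cc1` gives 39000 nM.
Compound 3 `COc1ccc(C2CC(c3ccco3)=NN2C(C)=O)cc1` gives 15500 nM.

Compound 3 stands second highest of the three numbers. Its nearest neighbour is compound 1, whose number is lower but within the scatter of compound 3, so the two cannot be ranked. Compound 2 sits furthest away, above the scatter.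

Within the data shown here, the only single-change step measured is a 2.5-fold lower number from compound 2 to compound 3 (0.40 log units; beyond the scatter), a modest gain from changing the group on the aromatic carbon. Compound 4 `CC(=O)N1N=C(c2ccco2)CC1c1ccc(N(C)C)cc1` arises from compound 3 by a change in the same place: dimethylamino in place of methoxy on an aromatic carbon. Compound 1 already carries this dimethylamino group, though on a different core, and its value in this assay sits below that of compound 3 only within the scatter, so it offers weak support at best.

Given the modest gain in a 2.5-fold lower number from compound 2 to compound 3 (0.40 log units; beyond the scatter) from altering this group, a similar or smaller step downward is expected, as a 1.9-fold lower number from compound 3 to compound 4 (0.29 log units; within the scatter). The estimate for compound 4 in this assay is therefore 8000 nM, with a range of 3000 nM to 22000 nM.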

Compound 4, half-maximal inhibitory concentration: 16700 nM
Beside the measured number, compound 4's estimate is 2.1-fold (0.32 log units) below it; the range from low to high includes it.
By their numbers in this assay, from the lowest: compounds 1, 3 and 4 (each within the scatter of the next, the first and the last beyond it); then compound 2.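

In this assay, dimethylamino in place of methoxy on this aromatic carbon gives a 1.1-fold higher number from compound 3 to compound 4 (0.03 log units; within the scatter), so on the shared core these two groups cannot be told apart. Compound 4 also stands clear of the chloro compound, with a 2.3-fold lower number from compound 2 to compound 4 (0.37 log units; beyond the scatter), which adds a second group to methoxy, seen earlier in a 2.5-fold lower number from compound 2 to compound 3 (0.40 log units; beyond the scatter), that gives a lower number than chloro at this position. With dimethylamino held fixed, the other place matters too, since furan-2-yl in place of phenyl gives a 2.1-fold higher number from compound 1 to compound 4 (0.33 log units; beyond the scatter), a modest change in the opposite direction. Nothing available explains any of these differences. As far as these compounds go, whether an unsubstituted amine or a carboxylic acid on this aromatic carbon would move the number beyond what methoxy and dimethylamino give remains open.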